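Swapping an aryl amine for a bis-hydroxypropyl amine

The source may hold more compounds than are shown below. What is called first, only, known or untested is meant among the compounds shown, and "the series" means these compounds.

Measured compounds in an ADME assay on A549 cells (Homo sapiens) for cytotoxicity, read by resazurin assay, with a stated time of 48 h; a higher number here means that more compound is tolerated, a lower number that less compound is tolerated:
compound 1, `O=C(Nc1ccc(NCC2CC2)cc1Cl)c1cc(Cl)ccc1O`, 14400 nM;
compound 2, `O=C(Nc1ccc(NCc2ccccc2)cc1Cl)c1cc(Cl)ccc1O`, 19700 nM;
compound 3, `O=C(Nc1ccc(NCc2ccc(Br)cc2)cc1Cl)c1cc(Cl)ccc1O`, 40900 nM.

Compound 3 gives the highest number of the three in this assay; its nearest neighbour is compound 2, reached by a 2.1-fold higher number from compound 2 to compound 3 (0.32 log units; beyond the scatter), and the step of a 2.8-fold higher number from compound 1 to compound 3 (0.45 log units; beyond the scatter) is the wider one. The step of a 1.4-fold higher number from compound 1 to compound 2 (0.14 log units; within the scatter) lies within the scatter.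

Compound 4, `O=C(Nc1ccc(N(CCCO)CCCO)cc1Cl)c1cc(Cl)ccc1O`, differs from compound 3 by bis(3-hydroxypropyl)amino in place of (4-bromobenzyl)amino on an aromatic carbon. Within the data shown here, two measured steps touch the same part of the molecule: a 2.8-fold higher number from compound 1 to compound 3 (0.45 log units; beyond the scatter) and a 2.1-fold higher number from compound 2 to compound 3 (0.32 log units; beyond the scatter), each modest and both ending at compound 3. Neither step exchanges a ring for a pair of hydroxyalkyl chains, so the data give only a sense of the scale: changes at this nitrogen have moved the number modestly, and compounds 1 and 2 sit below compound 3. The account therefore expects a modest move downward in this assay, back toward the range of compound 1 and compound 2, as a 2.6-fold lower number from compound 3 to compound 4 (0.41 log units; beyond the scatter). Compound 4 is estimated at 16000 nM in this assay, with a range from 6000 nM to 45000 nM.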

Compound 4, half-maximal cytotoxic concentration: 114000 nM
Beside the measured number, compound 4's estimate is 7.1-fold (0.85 log units) below it, outside the stated range (above it).
By their numbers in this assay, from the lowest: compounds 1 and 2 (each within the scatter of the next); then compound 3; then compound 4.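

In this assay, among these compounds, the aromatic carbon carrying these amino groups proves to have a wider reach than the earlier compounds suggested, since bis(3-hydroxypropyl)amino in place of (4-bromobenzyl)amino gives a 2.8-fold higher number from compound 3 to compound 4 (0.45 log units; beyond the scatter) and thereby extends the top of the series. The same group in place of benzylamino gives a 5.8-fold higher number from compound 2 to compound 4 (0.76 log units; beyond the scatter) and in place of (cyclopropylmethyl)amino gives a 7.9-fold higher number from compound 1 to compound 4 (0.90 log units; beyond the scatter) as the widest step in the set, so a group with oxygen and no ring now sets the upper end, ahead of the bromo-bearing benzyl group. The account has no measurement that would tie these steps to any cause.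

The compounds shown do not separate the part played by the hydroxyl groups from that of the loss of the ring or the second chain on the nitrogen, which a bis(3-methoxypropyl)amino group, a dipropylamino group or a single 3-hydroxypropylamino group would address. From the compounds shown here alone, it also stays open whether a shorter chain, as in bis(2-hydroxyethyl)amino, or a carboxylic acid at the chain end would hold the number this high.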